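Acetyl for benzoyl on the ring amide nitrogen, without methoxy

The compounds below may be only part of what the source reports. "The series", "measured", "known", "first", "only" and "open" are said of these compounds alone.

Compound 2 `CC1(C)SC(c2ccccc2N)=NN1C(=O)c1ccccc1` sits second highest of the three numbers in an assay on isolated protein for inhibition of Nitric oxide synthase, inducible (Homo sapiens), read by scintillation counting, with a stated time of 30 min, tested at 50 uM; a lower number here means less inhibition, a higher number more inhibition at the concentration tested (going by the name of the read-out): compound 2 gives 39.8%. Compound 1 `COc1ccc(N)c(C2=NN(C(C)=O)C(C)(C)S2)c1` gives 77.1%. Compound 3 `COc1ccc(N)c(C2=NN(C(=O)c3ccccc3)C(C)(C)S2)c1` gives 0%. Compound 4 `CC(=O)N1N=C(c2ccccc2N)SC1(C)C` has not been measured; it differs from compound 2 as follows: methyl in place of phenyl on a carbonyl carbon.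

For the measured compounds named here, two measured steps bear on this. The step of a number 77.1 percentage points lower from compound 1 to compound 3 (beyond the scatter) is the exact reverse of the change now considered, so the same swap in the other direction should raise inhibition strongly. The step of a number 39.8 percentage points lower from compound 2 to compound 3 (beyond the scatter) shows that the methoxy group, which compound 4 lacks, is itself associated with lower inhibition on the benzoyl pair, so no offset against the gain is indicated. Compound 4 is therefore expected to be well above compound 2 in this assay, with a step of about a number 35.2 percentage points higher from compound 2 to compound 4 (beyond the scatter), and an estimated value of 75%, plausibly between 50% and 95%. Going by the values given here, only one pair supports the size of the step, so the range is wide.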

Compound 4, a percentage reported as inhibition, at one concentration (the size of the read-out at that concentration, not a potency): 22.9%
The estimate for compound 4 lay 52.1 percentage points above the measured number, and the stated range ends above it.
By their numbers in this assay, from the lowest: compound 3; then compound 4; then compound 2; then compound 1.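

In this assay, methyl in place of phenyl on a carbonyl carbon has no single direction: without methoxy it gives a number 16.9 percentage points lower from compound 2 to compound 4 (beyond the scatter), the opposite of its direction with methoxy present: the same change on two cores in this assay, a number 77.1 percentage points lower (beyond the scatter) from compound 1 to compound 3 and a number 16.9 percentage points higher (beyond the scatter) from compound 4 to compound 2, 94 percentage points apart, beyond the scatter of two such steps The methoxy change also depends on its partner, since hydrogen in place of methoxy on an aromatic carbon gives a number 54.2 percentage points lower from compound 1 to compound 4 (beyond the scatter) on the acetyl pair, while methoxy goes with the lower number on the benzoyl pair: the same change on two cores in this assay, a number 39.8 percentage points lower (beyond the scatter) from compound 2 to compound 3 and a number 54.2 percentage points higher (beyond the scatter) from compound 4 to compound 1, 94 percentage points apart, beyond the scatter of two such steps The two changes therefore do not add, and among these four, high inhibition belongs to the combination of acetyl and methoxy in compound 1, at 77.1%.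

As far as these compounds go, whether this dependence extends to other carbonyl substituents, such as ethyl or cyclopropyl, or to ethoxy or fluorine in place of methoxy, remains open. Readings at one concentration also leave the potency of these compounds open.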